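This account rests on a few compounds, and the source may have more. Where it says the series, first, only, none or still open, it means among the compounds named here.

In a functional assay on MDA-MB-231 cells (Homo sapiens) for antiproliferative activity, read by MTT assay, with a stated time of 24 h (on this read-out lower numbers stand for stronger inhibition and higher numbers for weaker inhibition), compound 1 `Cc1ccccc1NNC(=O)c1ccc(NS(=O)(=O)c2cnc(O)nc2O)cc1` gives > 20000 nM, which is a limit of the assay and not a number. Compound 2 `Cc1cccc(NNC(=O)c2ccc(NS(=O)(=O)c3cnc(O)nc3O)cc2)c1` gives > 20000 nM, which is also a limit. Going by the values given here, compound 3 `O=C(NNC(=O)c1cccc(Cl)c1)c1ccc(NS(=O)(=O)c2cnc(O)nc2O)cc1` gives 4160 nM, the only actual number so far.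

Compound 4 `O=C(NNC(=O)c1ccccc1F)c1ccc(NS(=O)(=O)c2cnc(O)nc2O)cc1` differs from compound 3 in one place: 2-fluorophenyl in place of 3-chlorophenyl on a carbonyl carbon. Put simply, 2-fluorophenyl stands in place of 3-chlorophenyl on a carbonyl carbon.

The closest guides are the two steps that introduced the (3-chlorophenyl)carbonyl group: an at least 4.8-fold lower number from compound 1 to compound 3 (0.68 log units; beyond the scatter) and an at least 4.8-fold lower number from compound 2 to compound 3 (0.68 log units; beyond the scatter). Both replaced a methylphenyl group on an amine nitrogen, so neither measures a swap on the ring attached to the carbonyl carbon. Compound 4 keeps that carbonyl, so the gain seen in those two steps is expected to remain largely intact. The expected change is small and towards a higher number, with no shift beyond the scatter: a 1.4-fold higher number from compound 3 to compound 4 (0.16 log units; within the scatter). For compound 4 the estimate is 6000 nM, with an expected range from 2000 nM to 18000 nM.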

Compound 4, half-maximal inhibitory concentration: > 20000 nM
Compound 4 ended at the assay's limit; the forecaster's own chance of this, stated with the estimate: 20%; middle value at least 3.3-fold (0.52 log units) away from the limit.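

In this assay, the ring on the carbonyl carbon turns out to matter: 2-fluorophenyl in place of 3-chlorophenyl gives an at least 4.8-fold higher number from compound 3 to compound 4 (0.68 log units; beyond the scatter). The earlier steps shown here pointed to the (3-chlorophenyl)carbonyl group as a whole, whereas compound 4 keeps the carbonyl and still shows no measurable number, so the carbonyl alone does not bring the gain seen with compound 3. The steps from compound 1 and from compound 2 to compound 4 cannot be read, because both ends of each step sit at the same limit: the limit of > 20000 nM in this assay, at which 3 of the 4 values shown sit.

This swap changes both the halogen and its place on the ring, so the two effects cannot be separated here. A 2-chlorophenyl or a 3-fluorophenyl group would separate them, while a plain phenyl group would show whether the ring needs a halogen at all.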